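Compound 2 to compound 4: furan-2-yl replaces 3-chlorophenyl

The source may report more compounds than this note shows. Statements on the series, on what has been measured and on what is new or still open speak of the compounds shown alone.

Going by the values given here, in a functional assay on ECa-109 cells (Homo sapiens) for cytotoxicity, read by MTT assay, with a stated time of 72 h (a lower number here means a stronger inhibitor, a higher number a weaker inhibitor), compound 2 `O=C1C(=Cc2cccc(Cl)c2)C(=O)N(c2ccc(Cl)cc2)N1c1ccc(Cl)cc1` gives 22600 nM and sits in the middle of the three numbers so far. Compound 1 `COc1cc(C=C2C(=O)N(c3ccc(Cl)cc3)N(c3ccc(Cl)cc3)C2=O)ccc1O` gives the lower 7100 nM, and compound 3 `CC(=C1C(=O)N(c2ccc(Cl)cc2)N(c2ccc(Cl)cc2)C1=O)c1ccc(O)cc1` gives the higher 55600 nM. Compound 4 `O=C1C(=Cc2ccco2)C(=O)N(c2ccc(Cl)cc2)N1c1ccc(Cl)cc1` has not yet been measured in this assay. It differs from compound 2 as follows: furan-2-yl in place of 3-chlorophenyl on a double-bonded chain carbon bound to a double-bonded ring carbon. In words, this is furan-2-yl in place of 3-chlorophenyl on a double-bonded chain carbon bound to a double-bonded ring carbon. Among the compounds with values here, one measured step bears on that place: a 3.2-fold higher number from compound 1 to compound 2 (0.50 log units; beyond the scatter), with 3-chlorophenyl in place of 4-hydroxy-3-methoxyphenyl. That step is modest but beyond the scatter. Within the data shown here, no measured step brings in furan-2-yl, so the direction remains open and a change of similar size is taken as the outer expectation. The central estimate is a 1.2-fold lower number from compound 2 to compound 4 (0.08 log units; within the scatter), which is expected to stay within the scatter. For compound 4 the estimated value is 19000 nM, with an expected range of 7000 nM to 50000 nM.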

Compound 4, half-maximal inhibitory concentration: 14300 nM
The estimate for compound 4 lay 1.3-fold (0.12 log units) above the measured number; low and high end bracket the measured number.
By their numbers in this assay, from the lowest: compounds 1, 4 and 2 (each within the scatter of the next, the first and the last beyond it); then compound 3.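

In this assay, this place also accepts a five-membered aromatic ring with 1 hetero atom: furan-2-yl in place of 3-chlorophenyl gives a step within the scatter (a 1.6-fold lower number from compound 2 to compound 4 (0.20 log units; within the scatter)), and furan-2-yl in place of 4-hydroxy-3-methoxyphenyl does the same (a 2.0-fold higher number from compound 1 to compound 4 (0.30 log units; within the scatter)). Compound 4 therefore cannot be separated from compound 1 or compound 2, although those two stand apart beyond the scatter (a 3.2-fold higher number from compound 1 to compound 2 (0.50 log units; beyond the scatter)). Nothing available gives a reason for these numbers.

Still open, on these data alone, is whether furan-2-yl is special among five-membered rings or whether thiophen-2-yl or pyrrol-2-yl would read the same. As far as these compounds go, it is also open whether an aromatic ring is needed here at all, or whether a longer alkyl chain, an amine or a carboxylic acid at this place would keep the number in this range.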